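The source may hold more compounds than are shown below. What is called first, only, known or untested is meant among the compounds shown, and "the series" means these compounds.

Compound 1 `O=C(Nc1ccc(Br)cc1)c1cn(-c2ccccc2)nc1-c1ccccc1`, compound 2 `O=C(Nc1ccccc1)c1cn(-c2ccccc2)nc1-c1ccc(Cl)cc1` and compound 3 `O=C(Nc1ccc(Cl)cc1)c1cn(-c2ccccc2)nc1-c1ccc(Cl)cc1` share one core and differ only in the substituents on their two outer rings. In a functional assay on HCT-116 cells (Homo sapiens) for cytotoxicity, read by MTT assay, with a stated time of 48 h (a lower number here means a stronger inhibitor, a higher number a weaker inhibitor), compound 1 gives 4470 nM, compound 2 gives 2180 nM and compound 3 gives 2990 nM, so all three numbers lie within the scatter of one another and compound 3 sits between its two neighbours without separating from either. Among the compounds with values here, the one single-point step among them, a 1.4-fold higher number from compound 2 to compound 3 (0.14 log units; within the scatter), is likewise within the scatter.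

Compound 4 `O=C(Nc1ccc(Br)cc1)c1cn(-c2ccccc2)nc1-c1ccc(Cl)cc1` is compound 3 with bromo in place of chloro on an aromatic carbon. Within the data shown here, no measured step swaps these two halogens directly; compound 1 and compound 3 differ in two places at once and their values are within the scatter of each other. Compound 4 is therefore expected to show a 1.2-fold higher number from compound 3 to compound 4 (0.07 log units; within the scatter), no movement beyond the scatter. The estimate for compound 4 is 3500 nM, with a range from 1500 nM to 8000 nM.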

Compound 4, half-maximal inhibitory concentration: 4360 nM
The estimate for compound 4 lay 1.2-fold (0.10 log units) below the measured number; the range from low to high includes it.
By their numbers in this assay, from the lowest: compounds 2, 3, 4 and 1 (each within the scatter of the next, the first and the last beyond it).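

In this assay, within the data shown here, going from (4-chlorophenyl)amino to (4-bromophenyl)amino gives a 1.5-fold higher number from compound 3 to compound 4 (0.16 log units; within the scatter), the first direct reading of this halogen swap, and bromo in place of hydrogen on the same aromatic carbon gives a 2.0-fold higher number from compound 2 to compound 4 (0.30 log units; within the scatter), so at this place neither bromo nor chloro separates from the other or from hydrogen. The 4-chlorophenyl group on the other outer ring also leaves the number within the scatter, with a 1.0-fold lower number from compound 1 to compound 4 (0.01 log units; within the scatter). Chloro in place of hydrogen, read on two cores, gives steps that do not separate from each other: the same change on two cores in this assay, a 1.4-fold higher number (0.14 log units; within the scatter) from compound 2 to compound 3 and a 1.0-fold lower number (0.01 log units; within the scatter) from compound 1 to compound 4, 1.4-fold (0.15 log units) apart, within the scatter of two such steps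

The compounds shown leave open whether a group of another kind on these outer rings, such as an amine, a methoxy group or a carboxylic acid, would move the number beyond the scatter.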